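Adding a hydroxy group to a thiourea inhibitor

This account rests on a few compounds, and the source may have more. Where it says the series, first, only, none or still open, it means among the compounds named here.

Going by the values given here, compound 1 `S=C(Nc1ccccc1)Nc1ccc2[nH]ccc2c1` is one of two compounds measured in an assay on cells for inhibition of Amine oxidase [flavin-containing] B (Homo sapiens), read by spectrophotometry (on this read-out higher numbers stand for weaker inhibition and lower numbers for stronger inhibition), where compound 1 gives 60000 nM, the highest of the two numbers. Among the compounds with values here, its only neighbour, compound 2 `Oc1ccccc1NC(=S)Nc1ccc2[nH]ccc2c1`, gives 4000 nM in this assay. Within the data shown here, the step of a 15-fold lower number from compound 1 to compound 2 (1.18 log units; beyond the scatter) is the only measured step and shows what a hydroxy group on that ring can do. Compound 3 `Oc1ccc(NC(=S)Nc2ccc3[nH]ccc3c2)cc1` differs from compound 1 by hydroxy in place of hydrogen on an aromatic carbon. Among the measured compounds shown here, this is the same kind of group on the same ring as in compound 2, but the attachment point is not the same, and no measured pair tells whether the gain carries over. The expectation is therefore a step in the same direction, somewhat smaller and less certain, so that compound 3 is expected to show a 4.0-fold lower number from compound 1 to compound 3 (0.60 log units; beyond the scatter). Compound 3 is estimated at 15000 nM, within a range from 3000 nM to 60000 nM.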

Compound 3, half-maximal inhibitory concentration: 17000 nM
Estimate against measurement, compound 3: 1.1-fold (0.05 log units) below; measured number inside the range.
By their numbers in this assay, from the lowest: compound 2; then compound 3; then compound 1.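

A hydroxy group para to a large group also lowers the number, with a 3.5-fold lower number from compound 1 to compound 3 (0.55 log units; beyond the scatter) as the step, so the gain seen with compound 2 is not tied to a single attachment point on this ring. The two placements do not give the same number, though: compound 2 stands at 4000 nM and compound 3 stands at 17000 nM in the same assay, so the lower number belongs to the placement in compound 2. Nothing shown here bears on why a hydroxy group on this ring lowers the number.

Still open, from the compounds shown here alone, is whether a hydroxy group is specifically needed, or whether an amine or a methoxy group at the same place would give a similar number. These three compounds also cannot tell whether the same change would act alike on a different core.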